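The source may hold more compounds than are shown below. What is called first, only, known or untested is meant among the compounds shown, and "the series" means these compounds.

Measured so far in a physicochemical assay for solubility, read by spectrophotometry, in phosphate buffer, with a stated time of 2 h, at pH 7.4; on this read-out higher numbers stand for higher solubility and lower numbers for lower solubility:

compound 1 `COc1ccc2[nH]c(C(=O)N3CC(=O)N(Cc4ccccc4)[C@@H](CN4CCC(C)CC4)C3)cc2c1` — 93100 nM
compound 2 `COc1ccc2[nH]c(C(=O)N3CC(=O)N(Cc4c[nH]c5ccccc45)[C@@H](Cc4ccccc4)C3)cc2c1` — 10300 nM

Compound 1 stands highest of the two numbers; compound 2 gives the lower number, and the gap between the two is beyond the scatter. Going by the values given here, the two compounds differ in more than one place, so no single step connects them; only their two values are known.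

Compound 3 `COc1ccc2[nH]c(C(=O)N3CC(=O)N(Cc4ccccc4)[C@@H](COc4ccc(F)cc4)C3)cc2c1` is the next entry, not yet measured in this assay. Relative to compound 1 the change is 4-fluorophenoxy in place of 4-methylpiperidin-1-yl on a saturated chain carbon bound to a saturated ring carbon. Cut one bond further out, the same change reads (4-methylpiperidin-1-yl)methyl to (4-fluorophenoxy)methyl: a ring with one nitrogen and no aromatic character leaves, and a six-membered aromatic ring of carbon only, bearing fluorine, enters through an oxygen.

Among the compounds with values here, with no measured step of this kind on record, the expectation rests on the two values alone. Compound 2, which carries aromatic rings at both of the corresponding positions, gives the lower number; compound 3 is expected to move in that direction, with a step of about a 6.2-fold lower number from compound 1 to compound 3 (0.79 log units; beyond the scatter) beyond the scatter. For compound 3 the estimated solubility is 15000 nM, within a range of 4000 nM to 50000 nM.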

Compound 3, solubility: 17500 nM
Compound 3: middle estimate off by 1.2-fold (0.07 log units), on the low side; the range from low to high includes it.
By their numbers in this assay, from the lowest: compounds 2 and 3 (each within the scatter of the next); then compound 1.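

In this assay, the series now has its first step that can be read at a single place: on a saturated chain carbon bound to a saturated ring carbon, 4-fluorophenoxy in place of 4-methylpiperidin-1-yl gives a 5.3-fold lower number from compound 1 to compound 3 (0.73 log units; beyond the scatter), so the read-out responds to a change at this position. The step replaces one six-membered non-aromatic ring with 1 hetero atom by one six-membered aromatic ring of carbon only, while the hydrogen-bond donor and acceptor counts of the two groups match and neither group carries a net charge, which means those counts do not distinguish the pair. No measurement on hand bears on what lies behind this step.

The change alters the ring, the atom linking it to the chain and the fluorine all at once, and the compounds shown do not separate these three contributions. From the compounds shown here alone, an unsubstituted phenoxy, a morpholin-4-yl or a carboxylic acid at this place would show which part of the change carries the step, and whether it holds beyond this pair remains open.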